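Compound 3: a swap on the aromatic amine

This account rests on a few compounds, and the source may have more. Where it says the series, first, only, none or still open, it means among the compounds named here.

Measured so far:
Compound 1 (`COc1ccc(Nc2nc(N[C@H]3CC[C@H](N)CC3)nc3c2ncn3CCC(C)C)c(OC)c1`): 7900 nM
Compound 2 (`N[C@H]1CC[C@H](Nc2nc(Nc3ccc(Cl)cc3)c3ncn(C4CCCCC4)c3n2)CC1`): 4100 nM

In a functional assay on BT-474 cells (Homo sapiens) for inhibition, read by fluorescence, with a stated time of 72 h (on this read-out lower numbers stand for stronger inhibition of growth and higher numbers for weaker inhibition of growth), compound 1 stands within the usual scatter of compound 2 and no order can be read between the two. Compound 3 (`CC(C)CCn1cnc2c(Nc3cccc(O)c3)nc(N[C@H]3CC[C@H](N)CC3)nc21`) has not yet been measured. It differs from compound 1 in one place: 3-hydroxyphenyl in place of 2,4-dimethoxyphenyl on a nitrogen on an aromatic ring with 3-hydroxyphenyl in place of 2,4-dimethoxyphenyl on a nitrogen on an aromatic ring. Among the compounds with values here, no measured pair shows what this swap does, so the two values offer only a general level. The expected change a 2.6-fold lower number from compound 1 to compound 3 (0.42 log units; beyond the scatter) is a modest move toward stronger inhibition in this assay and may not clear the scatter by much. Compound 3 is estimated at 3000 nM with a range of 800 nM to 10000 nM as the expected span.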

Compound 3, concentration for 50% growth inhibition: 14700 nM
Compound 3: middle estimate off by 4.9-fold (0.69 log units), on the low side, and the stated range ends below it.
By their numbers in this assay, from the lowest: compounds 2, 1 and 3 (each within the scatter of the next, the first and the last beyond it).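

In this assay, the swap of 2,4-dimethoxyphenyl for 3-hydroxyphenyl on a nitrogen on an aromatic ring gives a 1.9-fold higher number from compound 1 to compound 3 (0.27 log units; within the scatter), the first step read directly at this position. Compound 1 and compound 3 therefore cannot be put in order, even though the group that enters brings a hydrogen-bond donor and the group that leaves has none. Nothing given here accounts for this result.

Compound 2 differs from compound 1 and from compound 3 in more than one place, so its steps to them cannot be read, and the part played by its 4-chlorophenyl group on that nitrogen stays unsettled. Going by these compounds, it also remains open how this position would respond to a group such as 3-aminophenyl, 3-carboxyphenyl or a longer chain in place of the aromatic ring.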